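The compounds below may be only part of what the source reports. "The series", "measured", "known", "first", "only" and "open" are said of these compounds alone.

Three measured compounds share one core and differ only in the aryl group on a saturated chain carbon bound to an aromatic nitrogen. Compound 1 `Cc1ccccc1Cn1cc(COc2ccc3c(=O)ccoc3c2)nn1` carries 2-methylphenyl; in a functional assay on QGY7701 cells (Homo sapiens) for cytotoxicity, read by MTT assay, with a stated time of 48 h (on this read-out higher numbers stand for weaker inhibition and lower numbers for stronger inhibition), compound 1 gives no number, only the limit > 100000 nM (the limit of > 100000 nM in this assay, at which 1 of the 3 values shown sits). Compound 2 `O=c1ccoc2cc(OCc3cn(Cc4ccc(F)cc4)nn3)ccc12` gives 14400 nM and compound 3 `O=c1ccoc2cc(OCc3cn(Cc4cccc([N+](=O)[O-])c4)nn3)ccc12` gives 14100 nM. Compound 3 and compound 2 sit within the scatter of each other, a 1.0-fold lower number from compound 2 to compound 3 (0.01 log units; within the scatter). Both leave the limit: an at least 6.9-fold lower number from compound 1 to compound 2 (0.84 log units; beyond the scatter) and an at least 7.0-fold lower number from compound 1 to compound 3 (0.85 log units; beyond the scatter). Compound 4 `N#Cc1ccc(Cn2cc(COc3ccc4c(=O)ccoc4c3)nn2)cc1` differs from compound 3 by 4-cyanophenyl in place of 3-nitrophenyl on a saturated chain carbon bound to an aromatic nitrogen. The step that bears on this is a 1.0-fold lower number from compound 2 to compound 3 (0.01 log units; within the scatter), an aryl swap of the same kind, so compound 4 is expected to show no step beyond the scatter, a 1.1-fold higher number from compound 3 to compound 4 (0.03 log units; within the scatter). Compound 4 is estimated at 15000 nM, range 5000 nM to 45000 nM.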

Compound 4, half-maximal inhibitory concentration: > 100000 nM
Compound 4: a limit, no number (the forecaster's own chance of this, stated with the estimate: 10%); at least 6.6-fold (0.82 log units) between middle value and limit.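

In this assay, the aryl group at this place proves able to move the read-out, which the step between compound 2 and compound 3 did not show: 4-cyanophenyl in place of 3-nitrophenyl gives an at least 7.0-fold higher number from compound 3 to compound 4 (0.85 log units; beyond the scatter). Cyano in place of fluoro on an aromatic carbon, a single change, gives an at least 6.9-fold higher number from compound 2 to compound 4 (0.84 log units; beyond the scatter). Compound 4 gives a limit and no number, and the step from compound 1 to compound 4 cannot be read: the limit of > 100000 nM in this assay, at which 2 of the 4 values shown sit.

Going by these compounds, how an amine or a carboxylic acid on the phenyl ring would read remains open. So does a longer chain in place of the saturated chain carbon bound to the aromatic nitrogen.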